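Will a 3-carboxyazetidin-1-yl group clear the limit?

The compounds below may be only part of what the source reports. "The series", "measured", "known", "first", "only" and "open" are said of these compounds alone.

Values in a functional assay on HeLa cells (Homo sapiens) for antiproliferative activity, read by CCK-8 assay, with a stated time of 48 h; on this read-out lower numbers stand for stronger inhibition and higher numbers for weaker inhibition (each one a limit, not a number)
compound 1 `COc1ccc(/C=C\c2cc(OC)c(OC)c(OC)c2)cc1OCc1ccc(CN2C[C@H](O)C[C@@H]2C(=O)O)cc1` gives > 10000 nM
compound 2 `COc1ccc(/C=C\c2cc(OC)c(OC)c(OC)c2)cc1OCc1ccc(CN2CCCC[C@H]2C(=O)O)cc1` gives > 10000 nM
compound 3 `COc1ccc(/C=C\c2cc(OC)c(OC)c(OC)c2)cc1OCc1ccc(CN[C@H](C(=O)O)[C@H](C)O)cc1` gives > 10000 nM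

Compound 3 gives no number to start from (the limit of > 10000 nM in this assay, at which 3 of the 3 values shown sit). Compound 4 `COc1ccc(/C=C\c2cc(OC)c(OC)c(OC)c2)cc1OCc1ccc(CN2CC(C(=O)O)C2)cc1` carries 3-carboxyazetidin-1-yl in place of (1-carboxy-2-hydroxypropyl)amino on a saturated chain carbon bound to an aromatic carbon. Three earlier swaps at this same place bear on it (a step that the two limits leave unreadable from compound 1 to compound 2, a step that the two limits leave unreadable from compound 1 to compound 3 and a step that the two limits leave unreadable from compound 2 to compound 3). None of them has a readable size, and none produced a number. No clear step in either direction is therefore expected in this assay, and another limit is the likeliest report. The expected step is small (a step that the limit leaves unreadable from compound 3 to compound 4). The estimate for compound 4 is 12000 nM (range 5000 nM to 30000 nM).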

Compound 4, half-maximal inhibitory concentration: 6500 nM
For compound 4 the middle estimate is 1.8-fold (0.27 log units) above the measured one; the range from low to high includes it.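

With 3-carboxyazetidin-1-yl on the saturated chain carbon bound to an aromatic carbon, compound 4 is the only compound shown that gives a number in this assay, and the others stop at a limit: the limit of > 10000 nM in this assay, at which 3 of the 4 values shown sit. The steps to it read (an at least 1.5-fold lower number from compound 3 to compound 4 (0.18 log units; that floor lies within the scatter)), (an at least 1.5-fold lower number from compound 2 to compound 4 (0.18 log units; that floor lies within the scatter)) and (an at least 1.5-fold lower number from compound 1 to compound 4 (0.18 log units; that floor lies within the scatter)). Each is a floor within the scatter, so no real difference is established, and the steps among compounds 1, 2 and 3 cannot be read.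

Still open, going by these compounds, is what this place gives without the carboxylic acid, for example with a methyl ester or an amide on the same four-membered ring.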